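A few compounds are considered here, and "the series" means these few. Any claim that something is new, unique, unknown or untested is made for them only; others in the source may bear on it.

Three compounds of this series carry results in a functional assay on HCT-116 cells (Homo sapiens) for cytotoxicity, read by MTT assay, with a stated time of 72 h; on this read-out higher numbers stand for weaker inhibition and lower numbers for stronger inhibition. Compound 1, `O=C(NCCO)c1cc2ccc(OCc3ccc([N+](=O)[O-])cc3)cc2oc1=O`, gives 33400 nM. Compound 2, `O=C(NCCNC(=O)c1cc2ccc(OCc3ccc([N+](=O)[O-])cc3)cc2oc1=O)c1cc2ccc(OCc3ccc([N+](=O)[O-])cc3)cc2oc1=O`, gives 68100 nM. Compound 3, `CCN(CC)c1ccc2cc(C(=O)NC(C)C)c(=O)oc2c1`, gives only > 100000 nM, which is a limit of the assay and not a number; this is the limit of > 100000 nM in this assay, at which 1 of the 3 values shown sits. Compound 3 therefore stands at the edge of the range covered, and where it truly sits beyond that limit is not known from the numbers shown.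

The next compound, compound 4, `CCN(CC)c1ccc2cc(C(=O)N/N=C(/C)c3cccs3)c(=O)oc2c1`, is compound 3 with a single change: a group of 8 heavy atoms (6 carbon, 1 nitrogen, 1 sulfur; one five-membered aromatic ring with 1 hetero atom) in place of a group of 3 heavy atoms (3 carbon; no ring), on an amide-type nitrogen. No step between measured compounds is available for comparison, and the starting point is itself a limit, so no size of step can be read from the numbers shown; any expectation rests on the position of compound 3 alone. Compound 4 is expected to give 40000 nM in this assay, within 10000 nM to 150000 nM. The expected step is then an at least 2.5-fold lower number from compound 3 to compound 4 (0.39 log units; beyond the scatter), with a real chance that only a limit is reported again.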

Compound 4, half-maximal inhibitory concentration: > 100000 nM
Compound 4 was reported as a limit (the forecaster's own chance of this, stated with the estimate: 40%); middle value at least 2.5-fold (0.39 log units) away from the limit.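

No step can be read from compound 3 to compound 4, since both are reported only as limits: the limit of > 100000 nM in this assay, at which 2 of the 4 values shown sit.

As far as these compounds go, whether the thiophene-bearing group in place of isopropyl changes the read-out at all, and how far beyond the limit either compound lies, stays open.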